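Isopropyl for Methyl at the Double-Bonded Ring Carbon

A few compounds are considered here, and "the series" means these few. Any claim that something is new, unique, unknown or untested is made for them only; others in the source may bear on it.

Of the compounds shown here, two have numbers so far. Compound 1 `COC(=O)C1=C(C(C)C)NC(=O)N(C(=O)C(C)C)C1c1cccc([N+](=O)[O-])c1` gives 56600 nM in an assay on HEK293 cells for antagonist activity at Voltage-dependent L-type calcium channel subunit alpha-1C (Oryctolagus cuniculus), read by FLIPR; a lower number here means a stronger inhibitor, a higher number a weaker inhibitor. Compound 2 `COC(=O)C1=C(C)NC(=O)N(C(=O)OC(C)C)C1c1cccc([N+](=O)[O-])c1` gives 2480 nM in this assay, the lower of the two numbers, beyond the scatter from compound 1. Compound 3 `COC(=O)C1=C(C(C)C)NC(=O)N(C(=O)OC(C)C)C1c1cccc([N+](=O)[O-])c1` has not been measured; it differs from compound 2 by isopropyl in place of methyl on a double-bonded ring carbon. Going by the values given here, compound 1 also carries isopropyl at that carbon, but it differs from compound 2 elsewhere as well, so no single step covers this change. A weakening is expected, a 3.2-fold higher number from compound 2 to compound 3 (0.51 log units; beyond the scatter), partly because compound 1 gives 56600 nM. The estimate for compound 3 is 8000 nM, between 2500 nM and 30000 nM.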

Compound 3, half-maximal inhibitory concentration: 10400 nM
Compound 3: middle estimate off by 1.3-fold (0.11 log units), on the low side; low and high end bracket the measured number.
By their numbers in this assay, from the lowest: compound 2; then compound 3; then compound 1.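

In this assay, the step shows that moving from methyl to isopropyl on the double-bonded ring carbon weakens the compound, giving a 4.2-fold higher number from compound 2 to compound 3 (0.62 log units; beyond the scatter) on an otherwise unchanged structure. With isopropyl fixed at that carbon, isopropoxy in place of isopropyl on the carbonyl carbon gives a 5.4-fold lower number from compound 1 to compound 3 (0.74 log units; beyond the scatter) in the other direction, so the gap between compound 1 and compound 2 now divides into two separate steps. Nothing available accounts for either step. The compounds shown leave open how an ethyl or a cyclopropyl group, or a longer chain, would read at the double-bonded ring carbon.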